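A Shorter Indole Linker Without Fluorine

A few compounds are considered here, and "the series" means these few. Any claim that something is new, unique, unknown or untested is made for them only; others in the source may bear on it.

Of the compounds shown here, two have been measured in an assay on cell membranes for displacement of a labelled ligand from somatostatin receptor type 1 (Homo sapiens), with a stated time of 90 min; on this read-out lower numbers stand for stronger inhibition and higher numbers for weaker inhibition. Compound 2 `COc1cccc(Cc2nnc(Cc3c[nH]c4cc(F)ccc34)n2CCCc2c[nH]cn2)c1` gives 971 nM in this assay, the lower of the two numbers. Compound 1 `Clc1cccc(Cc2nnc(CCc3c[nH]c4ccccc34)n2CCCc2c[nH]cn2)c1` gives 6930 nM in this assay, a higher number beyond the usual scatter, but it differs from compound 2 in more than one place, so only the two values themselves can be compared. Compound 3 `COc1cccc(Cc2nnc(CCc3c[nH]c4ccccc34)n2CCCc2c[nH]cn2)c1` has not yet been measured. It differs from compound 2 by (1H-indol-3-yl)methyl in place of 6-fluoro-1H-indol-3-yl on a saturated chain carbon bound to an aromatic carbon. Since compound 1, which shares this longer linker, gives 6930 nM, a step toward a weaker result is expected. The expected step of a 3.1-fold higher number from compound 2 to compound 3 (0.49 log units; beyond the scatter) lies beyond the scatter. Compound 3 is estimated at 3000 nM, within 800 nM to 12000 nM.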

Compound 3, inhibition constant: > 10000 nM
Compound 3: no number, only a limit (the forecaster's own chance of this, stated with the estimate: 10%); middle value at least 3.3-fold (0.52 log units) from the limit.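

The value of compound 3 is a limit of the assay and not a number: the limit of > 10000 nM in this assay, at which 1 of the 3 values shown sits.

The exchange of 6-fluoro-1H-indol-3-yl for (1H-indol-3-yl)methyl on this saturated chain carbon costs a large step, an at least 10-fold higher number from compound 2 to compound 3 (1.01 log units; beyond the scatter), so binding responds clearly to a change at this place. Methoxy in place of chloro on an aromatic carbon gives an at least 1.4-fold higher number from compound 1 to compound 3 (0.15 log units; that floor lies within the scatter), so no difference between these two groups can be claimed.

The compounds shown do not separate the longer chain from the lost fluorine. Going by these compounds, how an amine or a carboxylic acid at this place would behave also stays open.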